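Aryl amide series: oxazole to chlorofluorophenyl swap

The source may report more compounds than this note shows. Statements on the series, on what has been measured and on what is new or still open speak of the compounds shown alone.

Compound 2 `O=C(Nc1ccc(Cl)c(-c2nnc3c(Cl)cccn23)c1)c1ccon1` carries a 1,2-oxazol-3-yl on the carbonyl carbon. In a functional assay on AN3-CA cells (Homo sapiens) for antiproliferative activity, read by MTT assay, with a stated time of 72 h (a higher number here means a weaker inhibitor, a lower number a stronger inhibitor), compound 2 gives > 100000 nM, which is a limit of the assay and not a number. Compound 1 `O=C(Nc1ccc(Cl)c(-c2nnc3c(Cl)cccn23)c1)c1ccc(Cl)cc1` likewise sits at a limit: in this assay compound 1 gives > 100000 nM. The step that the two limits leave unreadable from compound 1 to compound 2 therefore cannot be read, since the limit of > 100000 nM in this assay, at which 2 of the 2 values shown sit, places both values at the same limit.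

Compound 3 `O=C(Nc1ccc(Cl)c(-c2nnc3c(Cl)cccn23)c1)c1c(F)cccc1Cl` differs from compound 2 by 2-chloro-6-fluorophenyl in place of 1,2-oxazol-3-yl on a carbonyl carbon. For the measured compounds named here, no measured step bears on this change; the only step on record, from compound 1 to compound 2, runs between two limits and gives no size. The exchange of a 4-chlorophenyl for a 1,2-oxazol-3-yl left both compounds at the limit, and a return to a six-membered aromatic ring of carbon only carries no guarantee of a readable value.

Compound 3 is expected to give 100000 nM in this assay, with a range from 40000 nM to 250000 nM. The expected step of a number no higher from compound 2 to compound 3 (the limit leaves the size open) is nothing beyond the scatter, so a limit is anticipated again.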

Compound 3, half-maximal inhibitory concentration: > 100000 nM
Compound 3: only a limit was reported (the forecaster's own chance of this, stated with the estimate: 85%); the middle value sits exactly at the limit.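

No step can be read among compound 1, compound 2 and compound 3 in this assay, because each value is a limit and not a number: the limit of > 100000 nM in this assay, at which 3 of the 3 values shown sit.

The compounds shown leave open how 4-chlorophenyl, 1,2-oxazol-3-yl and 2-chloro-6-fluorophenyl on the carbonyl carbon compare, and whether any group there gives a readable value on this shared core.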